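Dimethylcarbamoyl in place of oxolan-2-yl on the side chain

The source may hold more compounds than are shown below. What is called first, only, known or untested is meant among the compounds shown, and "the series" means these compounds.

Compound 2 `Cn1cc(-c2ccc(NC(=O)c3cn(CC4CCCO4)cc(-c4ccc(F)cc4)c3=O)cc2)c2c(N)ncnc21` is the reference point here: in an assay on isolated protein for inhibition of tyrosine-protein kinase receptor UFO (Homo sapiens), read by ELISA (a higher number here means a weaker inhibitor, a lower number a stronger inhibitor), compound 2 gives 1.2 nM, the only number shown. Compound 1 `COCCCn1cc(C(=O)Nc2ccc(-c3cn(C)c4ncnc(N)c34)cc2)c(=O)c(-c2ccc(F)cc2)c1` carries a 2-methoxyethyl group at the same place, and in this assay compound 1 gives > 10 nM, which is a limit of the assay and not a number (the limit of > 10 nM in this assay, at which 1 of the 2 values shown sits). Between them stands one measured step, an at least 8.3-fold lower number from compound 1 to compound 2 (0.92 log units; beyond the scatter), read against that limit (the limit of > 10 nM in this assay, at which 1 of the 2 values shown sits).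

Compound 3 `CN(C)C(=O)Cn1cc(C(=O)Nc2ccc(-c3cn(C)c4ncnc(N)c34)cc2)c(=O)c(-c2ccc(F)cc2)c1` has not been measured in this assay. It differs from compound 2 by dimethylcarbamoyl in place of oxolan-2-yl on a saturated chain carbon bound to an aromatic nitrogen. Going by the values given here, only the step from compound 1 to compound 2 bears on this change, and it ran in favour of the ring; compound 3, like compound 1, has no ring at that position, though the entering group is not the one that compound 1 carries. The expectation is therefore for a weaker number than compound 2, of modest size, with wide uncertainty. Compound 3 is expected at 6 nM, within 1.5 nM to 30 nM, an expected step of a 5.0-fold higher number from compound 2 to compound 3 (0.70 log units; beyond the scatter).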

Compound 3, half-maximal inhibitory concentration: 0.5 nM
Estimate against measurement, compound 3: 12-fold (1.08 log units) above; the whole stated range lies above it.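

In this assay, dimethylcarbamoyl in place of oxolan-2-yl gives a 2.4-fold lower number from compound 2 to compound 3 (0.38 log units; beyond the scatter), so a ring on the saturated chain carbon bound to the aromatic nitrogen is not needed for the lowest number among the compounds shown. Neither 2-methoxyethyl nor dimethylcarbamoyl has a ring, yet the change from the first to the second gives an at least 20-fold lower number from compound 1 to compound 3 (1.30 log units; beyond the scatter), so what matters at this position is which open group stands there, not merely that the ring is absent. That step is read against compound 1, whose value is a limit of the assay and not a number: the limit of > 10 nM in this assay, at which 1 of the 3 values shown sits.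

The three groups shown do not tell whether the lower number goes with the carbonyl of dimethylcarbamoyl, with its two methyl groups, or with the group as a whole. A methylcarbamoyl group, a carbamoyl group with its nitrogen in a pyrrolidine or morpholine ring, a carboxylic acid, or a longer chain ending in dimethylcarbamoyl would each separate these readings.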